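Swapping the pyridine arm of compound 1 for a methylpyrazole

A few compounds are considered here, and "the series" means these few. Any claim that something is new, unique, unknown or untested is made for them only; others in the source may bear on it.

Compound 1 `CCN(c1ccc(C#N)c(Cl)c1)c1cc(-c2ccncc2)ccc1C`: 2900 nM
Compound 2 `Cc1noc(C)c1-c1cccc(Oc2ccc(C#N)c(C(F)(F)F)c2)c1`: "not determined" (no result reported)

For the measured compounds named here, only one number is available in this set. Going by the values given here, in a functional assay on VCaP cells (Homo sapiens) for antiproliferative activity, read by CCK-8 assay, with a stated time of 6 days (on this read-out lower numbers stand for stronger inhibition and higher numbers for weaker inhibition), compound 1 gives 2900 nM, which puts it on the weak side of the scale, and it is the sole compound with a figure, since for compound 2 the entry in this assay reads "not determined" (no result reported). Compound 3 `CCN(c1ccc(C#N)c(Cl)c1)c1cc(-c2c[nH]nc2C)ccc1C` has not been measured yet and shares the core of compound 1, differing in a single spot.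

3-methyl-1H-pyrazol-4-yl in place of pyridin-4-yl on an aromatic carbon

Among the compounds with values here, no pair of measured compounds here differs in one place, so the size of this kind of step cannot be read from the data directly. Given that, the safest expectation is a step in this assay from compound 1 to compound 3 that is small, with a slight lean toward stronger inhibition, and possibly no change at all beyond the usual scatter. The step I expect is a 1.5-fold lower number from compound 1 to compound 3 (0.16 log units; within the scatter). Compound 3 is therefore estimated at 2000 nM, within a range from 400 nM to 10000 nM.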

Compound 3, half-maximal inhibitory concentration: 3190 nM
Beside the measured number, compound 3's estimate is 1.6-fold (0.20 log units) below it; the measured number falls inside the stated range.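

In this assay, for the compounds shown here, the swap of pyridin-4-yl for 3-methyl-1H-pyrazol-4-yl gives a 1.1-fold higher number from compound 1 to compound 3 (0.04 log units; within the scatter) and is the first step that can be read at this position, on the aromatic carbon para to a methyl group. It shows that this spot tolerates a five-membered aromatic ring carrying a hydrogen-bond donor in place of a six-membered aromatic ring without one, with the two numbers lying within the usual scatter of each other and both on the weak side of the scale. No measurement is at hand that could explain why these two rings read alike.

The compounds shown leave open whether any group at this position can move the number toward stronger inhibition, for example a carboxylic acid or a simple amine in place of the ring. Going by these compounds alone, they also leave open what the methyl group on the 3-methyl-1H-pyrazol-4-yl ring contributes, as no pair here separates that methyl from the ring that carries it.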